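The compounds below may be only part of what the source reports. "The series", "measured", "known", "first", "only" and "open" are said of these compounds alone.

Compounds measured so far, with their readings in the cytotoxicity test:

Compound 1 `OC[C@H]1O[C@@H](n2cnc3c(COc4ccccn4)ncnc32)[C@H](O)[C@@H]1O`: > 250000 nM
Compound 2 `O=c1ccccn1Cc1ncnc2c1ncn2[C@@H]1O[C@H](CO)[C@@H](O)[C@H]1O`: > 100000 nM
Compound 3 `OCCSCc1ncnc2c1ncn2[C@@H]1O[C@H](CO)[C@@H](O)[C@H]1O`: > 100000 nM

Every one of these readings is a limit of a functional assay on Huh-7 cells (Homo sapiens) for cytotoxicity, read by MTT assay, with a stated time of 3 days (on this read-out lower numbers stand for higher toxicity in this test and higher numbers for lower toxicity in this test), rather than a measured number. Compound 3 sits at the limit (the limit of > 100000 nM in this assay, at which 2 of the 3 values shown sit). Compound 2 shares that same limit. Compound 1 sits at the other limit (the limit of > 250000 nM in this assay, at which 1 of the 3 values shown sits). All three readings are limits. The steps between them cannot be sized: a step that the two limits leave unreadable from compound 1 to compound 2, a step that the two limits leave unreadable from compound 1 to compound 3 and a step that the two limits leave unreadable from compound 2 to compound 3 all stay unreadable.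

Compound 4 `OC[C@H]1O[C@@H](n2cnc3c(Cn4ccc5ccccc54)ncnc32)[C@H](O)[C@@H]1O` is the next compound. It differs from compound 3 by 1H-indol-1-yl in place of (2-hydroxyethyl)sulfanyl on a saturated chain carbon bound to an aromatic carbon. For the measured compounds named here, none of the measured steps can guide this change, since each one is shut in by limits. Compound 3 shows no toxicity up to its limit, and compound 4 is expected to stay near the same region, so a step of about a number no higher from compound 3 to compound 4 (the limit leaves the size open) in this assay is estimated. For compound 4 an estimate of 100000 nM in this assay is given, within a range from 20000 nM to 300000 nM.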

Compound 4, half-maximal cytotoxic concentration: > 250000 nM
Compound 4: no number, only a limit (the forecaster's own chance of this, stated with the estimate: 65%); middle value at least 2.5-fold (0.39 log units) away from the limit.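

In this assay, for the compounds shown here, compound 4 gives only a limit, > 250000 nM, and compound 1, compound 2 and compound 3 also give only limits, so no step to compound 4 can be read. Still open is the concentration at which any of these compounds turns toxic, and whether changing the group on the saturated chain carbon alters that concentration.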